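The compounds below may be only part of what the source reports. "The series", "measured", "known", "first", "only" and "open" are said of these compounds alone.

Measured compounds:

compound 1, `C[C@H]1[C@H](O)[C@@H](CO)O[C@H]1n1ccc(N)nc1=O` — 0.26 ug/mL
compound 2, `CC[C@@H]1C(O)[C@@H](CO)O[C@H]1n1ccc(N)nc1=O` — > 100 ug/mL
compound 3, `Cc1cn([C@@H]2O[C@H](CO)C(O)[C@H]2C)c(=O)[nH]c1=O` — 32 ug/mL

Of the compounds shown here, three have been tested in a functional assay on L1210 cells (Mus musculus) for inhibition; on this read-out lower numbers stand for stronger inhibition and higher numbers for weaker inhibition. Compound 1 gives 0.26 ug/mL, the lowest number of the set. Compound 3 gives 32 ug/mL, a far higher number, and the gap between compound 1 and compound 3 lies well beyond the usual scatter. For compound 2 the assay reports only a limit, > 100 ug/mL, and not a number; this is the limit described by the limit of > 100 ug/mL in this assay, at which 1 of the 3 values shown sits.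

The step under study leads from compound 1 to compound 4, `C[C@@H]1[C@H](O)[C@@H](CO)O[C@H]1n1ccc(N)nc1=O`. The difference is: the two compounds have the same atoms and bonds and differ only in configuration as drawn: 1 of 4 stereo elements differ; a stereocentre at a saturated ring carbon is drawn S in compound 1 and R in compound 4

For the measured compounds named here, no step between two measured compounds isolates this kind of change, so no measured size can be quoted. In this assay the account expects compound 4 to give a higher number than compound 1, that is weaker inhibition, with the step from compound 1 to compound 4 estimated at a 38-fold higher number from compound 1 to compound 4 (1.59 log units; beyond the scatter). The value of compound 4 is expected to be about 10 ug/mL, within a range from 0.5 ug/mL to 100 ug/mL, with a fair chance that only a limit is reported.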

Compound 4, half-maximal inhibitory concentration: 40 ug/mL
Compound 4: middle estimate off by 4.0-fold (0.60 log units), on the low side; measured number inside the range.
By their numbers in this assay, from the lowest: compound 1; then compounds 3 and 4 (each within the scatter of the next). At a limit, above all of these: compound 2.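

In this assay the change of this one stereocentre from S to R gives a 150-fold higher number from compound 1 to compound 4 (2.19 log units; beyond the scatter), a large step. For the compounds shown here, this is the first measured step at this saturated ring carbon, and nothing else changes along it: the fact that compounds 1 and 4 differ only in the configuration as drawn. The same atoms therefore do not by themselves give strong inhibition in this assay, and the configuration as drawn at this carbon separates compound 1 from compound 4.

The compounds shown leave open whether the same preference for the S configuration would hold with another group at this carbon, such as a fluorine atom or an amine. They also leave open how a change of configuration at any of the other stereocentres of compound 1 would compare with this step.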